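Pyrazole for Phenyl on the Amide Nitrogen

The source may hold more compounds than are shown below. What is called first, only, known or untested is meant among the compounds shown, and "the series" means these compounds.

Compound 2 `Cc1ccc(OCC(=O)N(Cc2cccs2)c2ccccc2)cc1` stands at the lower of the two numbers measured in an assay on HEK293 cells for agonist activity at transient receptor potential cation channel subfamily M member 8 (Homo sapiens), read by fluorescence and calcium flux, with a stated time of 15 min (a higher number here means that more compound is needed for the effect, a lower number that less compound is needed), where compound 2 gives 23 nM. Among the measured compounds shown here, its only neighbour, compound 1 `Cc1ccc(OCC(=O)N(Cc2cccs2)C(C)(C)C)cc1`, carries a tert-butyl group on the amide-type nitrogen instead, and in this assay compound 1 gives 11000 nM. For the measured compounds named here, the single step joining them, a 480-fold lower number from compound 1 to compound 2 (2.68 log units; beyond the scatter), shows how strongly that position responds when a saturated group gives way to an aromatic ring.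

Compound 3 `Cc1ccc(OCC(=O)N(Cc2cccs2)c2c[nH]nc2C)cc1` differs from compound 2 in one place: 3-methyl-1H-pyrazol-4-yl in place of phenyl on an amide-type nitrogen. Going by the values given here, no measured step covers the swap of one aromatic ring for another at this nitrogen; the step from compound 1 to compound 2 bears on it only insofar as an aromatic ring remains in place, which it does here. With the ring kept and only its atoms altered, a much smaller step than the measured one is expected, most likely a modest move to a higher number: a 3.0-fold higher number from compound 2 to compound 3 (0.48 log units; beyond the scatter). For compound 3 the estimated value in this assay is therefore 70 nM, within a range from 15 nM to 400 nM.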

Compound 3, half-maximal effective concentration: 0.4 nM
Compound 3: the middle estimate sits 180-fold (2.24 log units) above what was measured, and the stated range ends above it.
By their numbers in this assay, from the lowest: compound 3; then compound 2; then compound 1.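

In this assay, among the compounds shown here, the earlier compounds showed only that an aromatic ring on the amide-type nitrogen gives a far lower number than tert-butyl, whereas the exchange of one aromatic ring for another proves to be a large change in its own right: 3-methyl-1H-pyrazol-4-yl in place of phenyl gives a 58-fold lower number from compound 2 to compound 3 (1.76 log units; beyond the scatter) and so the identity of the ring matters, not just its presence. Measured against tert-butyl, the same place spans a 28000-fold lower number from compound 1 to compound 3 (4.44 log units; beyond the scatter) with the rest of the core unchanged, a wider span than the phenyl step had revealed. The entering ring counts a hydrogen-bond donor and a hydrogen-bond acceptor where phenyl counts none, but no measurement at hand connects either feature to the step.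

The compounds shown leave open whether the step belongs to the pyrazole ring itself or depends on its methyl group, which an unsubstituted 1H-pyrazol-4-yl ring would test. They also leave open how an imidazole or a pyridine ring would behave on this amide-type nitrogen.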